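Phenyl for methyl on the piperidine ring, second time

The source may hold more compounds than are shown below. What is called first, only, known or untested is meant among the compounds shown, and "the series" means these compounds.

Measured so far:
compound 1, `CC1CCN(c2nc(-c3ccccc3)nc3ccccc23)CC1`, 69%
compound 2, `c1ccc(-c2nc(N3CCC(c4ccccc4)CC3)c3ccccc3n2)cc1`, 85.3%
compound 3, `CC1CCN(c2nc(-c3ccc(Cl)cc3)nc3ccc(Br)cc23)CC1`, 55.1%

In a functional assay on the whole organism for inhibition, with Rattus norvegicus as the target, read by paw edema, with stated times of 4 days, 1 h and 2 h, at a dose of 100 mg/kg by the oral route (on this read-out lower numbers stand for less inhibition and higher numbers for more inhibition at the one dose given (going by the name of the read-out)), compound 1 gives 69%. Compound 2 differs from compound 1 by phenyl in place of methyl on a saturated ring carbon, and in this assay compound 2 gives 85.3%; the step of a number 16.3 percentage points higher from compound 1 to compound 2 (beyond the scatter). Compound 3 carries a different core from compound 1, and the difference between the two cores is not broken down here. In this assay compound 3 gives 55.1%, the lowest of the three numbers, with its distance to compound 1 and to compound 2 both beyond the scatter.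

Compound 4, `Clc1ccc(-c2nc(N3CCC(c4ccccc4)CC3)c3cc(Br)ccc3n2)cc1`, has not yet been measured. It differs from compound 3 by phenyl in place of methyl on a saturated ring carbon, the same change that leads from compound 1 to compound 2, on a place described in the same words, so it is the same change made on the core of compound 3. Whether a change of this kind carries over from one core to another is known only from that single pair. Resting on the step of a number 16.3 percentage points higher from compound 1 to compound 2 (beyond the scatter), compound 4 is expected to show a step of about a number 14.9 percentage points higher from compound 3 to compound 4 (beyond the scatter) in this assay, a step of similar size to the earlier one. Compound 4 is therefore estimated at 70% in this assay, with a plausible range from 57% to 84%.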

Compound 4, a percentage reported as inhibition, in the whole organism at one dose (the size of the read-out at that dose, not a potency): 50%
The estimate for compound 4 lay 20 percentage points above the measured number; measured number below the stated range.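

In this assay, going by these compounds alone, phenyl in place of methyl on a saturated ring carbon gives a number 5.1 percentage points lower from compound 3 to compound 4 (within the scatter), so on the core of compound 3 the change produces no step that stands clear of the scatter. The rise seen on the core of compound 1 therefore did not carry over to the core of compound 3: the same change on two cores in this assay, a number 16.3 percentage points higher (beyond the scatter) from compound 1 to compound 2 and a number 5.1 percentage points lower (within the scatter) from compound 3 to compound 4, 21.4 percentage points apart, beyond the scatter of two such steps

Across these four compounds, then, the outcome of this change depends on the core that carries it, but the two pairs do not show which part of the difference between the cores matters, and they give no rule for any further core, for another dose or for another read-out.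

The compounds shown leave open how the step would read on a core carrying only the chlorine or only the bromine found in compound 3. They also leave open what an amine, a carboxylic acid or a longer chain would do in place of the phenyl on that saturated ring carbon, on either core.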